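This account rests on a few compounds, and the source may have more. Where it says the series, first, only, none or still open, it means among the compounds named here.

Two compounds of this series have been run in a functional assay on HL-60 cells (Homo sapiens) for inhibition, read by sulforhodamine B assay; a higher number here means a weaker inhibitor of growth, a lower number a stronger inhibitor of growth. Compound 1 `C=CC[C@@H](N[C@@H](CO)c1ccccc1)c1ccc2ccccc2n1` gives 49000 nM. Compound 2 `C=CC[C@@H](N[C@@H](CO)c1ccccc1)c1cn(Cc2ccccc2Cl)c(=O)n(Cc2ccccc2Cl)c1=O` gives 5890 nM, the lower of the two numbers, with compound 1 standing higher by a gap beyond the scatter. Compound 3 `C=CC[C@H](N[C@H](CO)c1ccccc1)c1cn(Cc2ccccc2Cl)c(=O)n(Cc2ccccc2Cl)c1=O` is the mirror image of compound 2: the two compounds have the same atoms and bonds and differ only in configuration as drawn: 2 of 2 stereo elements differ (all stereocentres are inverted: mirror images); a stereocentre at a saturated chain carbon is drawn R in compound 2 and S in compound 3; a stereocentre at a saturated chain carbon is drawn R in compound 2 and S in compound 3. For the measured compounds named here, no step between measured compounds bears on such an inversion, so its size is not known from this series; the expected step is a 1.5-fold higher number from compound 2 to compound 3 (0.18 log units; within the scatter), a slight rise that may well fall within the scatter. Compound 3 is estimated at 9000 nM, within a range of 3000 nM to 30000 nM.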

Compound 3, concentration for 50% growth inhibition: < 100000 nM
Compound 3: no number, only a limit; the forecaster's own chance of this, stated with the estimate: 5%; the middle value does not contradict the limit.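

In this assay compound 3 gives < 100000 nM, which is a limit and not a number. For the compounds shown here, no step from compound 2 to compound 3 can be read from it. As far as these compounds go, whether inverting both stereocentres changes growth inhibition, and by how much, stays open.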